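The source may report more compounds than this note shows. Statements on the series, on what has been measured and on what is new or still open speak of the compounds shown alone.

Working notes on the series. Within the data shown here, in an ADME assay on L929 cells (Mus musculus) for cytotoxicity, read by MTT assay, with a stated time of 24 h (a lower number here means that less compound is needed, a higher number that more compound is needed for the effect), compound 1 `COCCOCCOCCOCCOCCOCCOC(=O)Oc1c(C(C)C)cccc1C(C)C` gives 510000 nM, the second highest of the three numbers so far. Compound 2 `COCCOCCOCCOCC(=O)Oc1c(C(C)C)cccc1C(C)C` gives 650000 nM in this assay, which lies within the scatter of the number for compound 1; compound 3 `COCCOCCOCCOCCOCCOCCOCCOCC(=O)Oc1c(C(C)C)cccc1C(C)C` gives 120000 nM, the lowest of the three, and its number stands beyond the scatter from the other two. Compound 4 `COCCOCCOCCOCCOC(=O)Oc1c(C(C)C)cccc1C(C)C` is not yet measured and differs from compound 1 by hydrogen in place of (2-methoxyethoxy)methyl on a saturated chain carbon bound to an oxygen on a saturated carbon.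

Among the measured compounds shown here, the one measured step that bears on this change is the chain lengthening in this assay, a 5.4-fold lower number from compound 2 to compound 3 (0.73 log units; beyond the scatter), which went the other way round and to a lower number. A shortening of the chain might then be expected to raise the number, but the pair of compound 2 and compound 1 shows two numbers within the scatter of each other, so the effect of chain length is not consistent in the set. For compound 4 an estimate of 600000 nM, within a range of 300000 nM to 1200000 nM, is expected in this assay. This estimate means an expected step of a 1.2-fold higher number from compound 1 to compound 4 (0.07 log units; within the scatter), not beyond the scatter.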

Compound 4, half-maximal effective concentration: 1390000 nM
Estimate against measurement, compound 4: 2.3-fold (0.36 log units) below, outside the stated range (above it).
By their numbers in this assay, from the lowest: compound 3; then compounds 1 and 2 (each within the scatter of the next); then compound 4.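

In this assay the loss of (2-methoxyethoxy)methyl on a saturated chain carbon bound to an oxygen on a saturated carbon gives a 2.7-fold higher number from compound 1 to compound 4 (0.44 log units; beyond the scatter) and so makes compound 4 the highest number of the four. Chain length at this place therefore does move the number beyond the scatter in the pair with the core of compound 1, and the direction agrees with the earlier lengthening, a 5.4-fold lower number from compound 2 to compound 3 (0.73 log units; beyond the scatter), with the shorter chain higher in both pairs. No measurement at hand gives a reason for this step.

Open, as far as these compounds go, is whether a longer chain on the core of compound 1 continues the same direction or levels off. Also open, from the compounds shown here alone, is whether an amine or a carboxylic acid in place of the terminal methoxy keeps the number in the same range.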